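From a Fluorophenyl Carbonyl to a Methylpyrimidinyl Amine

A few compounds are considered here, and "the series" means these few. Any claim that something is new, unique, unknown or untested is made for them only; others in the source may bear on it.

This account concerns a small group of compounds that share a common core and were tested for antiproliferative activity in a functional assay on CWR22R cells (Homo sapiens) for antiproliferative activity, read by CCK-8 assay, with a stated time of 6 days; a higher number here means a weaker inhibitor, a lower number a stronger inhibitor. Among the compounds with values here, compound 1 `CC(=O)c1cc(C(=O)N[C@H](C)Cn2ccc(-c3cc(F)c(C#N)c(Cl)c3)n2)n[nH]1` is the only member of the group with a reported number: in this assay compound 1 gives 15500 nM, which places it among weak inhibitors. Compound 2 `C[C@@H](Cn1ccc(-c2ccc(C#N)c(Cl)c2)n1)NC(=O)c1ccccc1F` stands on no number at all in this assay, where the entry for compound 2 reads "not determined" (no result reported), and compound 3 `C[C@@H](Cn1ccc(-c2ccc(C#N)c(Cl)c2)n1)NC(=O)C1CC(=O)C1` likewise carries no reported value in this assay, the entry for compound 3 reading "not determined" (no result reported). Compound 2 therefore has no measured footing from which a step could be counted.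

Compound 4 `Cc1ccnc(N[C@@H](C)Cn2ccc(-c3ccc(C#N)c(Cl)c3)n2)n1` arises from compound 2 through a single change (4-methylpyrimidin-2-yl in place of (2-fluorophenyl)carbonyl on an amine nitrogen). Within the data shown here, because no step between measured compounds is available, the size of the expected shift in this assay cannot be anchored; the only reference is the weak result of compound 1 15500 nM, which differs from compound 4 in more than one place. The expectation is therefore that compound 4 remains a weak to moderate inhibitor, with no direction beyond the scatter claimed with confidence. Compound 4 is estimated to give 4000 nM in this assay, within a broad range from 500 nM to 30000 nM.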

Compound 4, half-maximal inhibitory concentration: 4760 nM
For compound 4 the middle estimate is 1.2-fold (0.08 log units) below the measured one, and the stated range covers the measured number.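

No step can be read from compound 2 to compound 4, as compound 4 gives 4760 nM in this assay while compound 2 has no single number there. The compounds shown leave open whether 4-methylpyrimidin-2-yl in place of (2-fluorophenyl)carbonyl on an amine nitrogen shifts activity in this assay, and in which direction. No evidence bears on this result.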